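Sulfur to selenium exchange on compound 3

A few compounds are considered here, and "the series" means these few. Any claim that something is new, unique, unknown or untested is made for them only; others in the source may bear on it.

Measured so far:
compound 1 `C[Se]/C(=N\C(=O)c1ccco1)NC(=O)c1ccco1` — 5940 nM
compound 2 `O=C(/N=C(/NC(=O)c1cc(-c2ccccc2)nc2ccccc12)[Se]Cc1ccccc1)c1cc(-c2ccccc2)nc2ccccc12` — 8460 nM
compound 3 `CS/C(=N\C(=O)c1cc(-c2ccccc2)nc2ccccc12)NC(=O)c1cc(-c2ccccc2)nc2ccccc12` — 40 nM

In an ADME assay on MCF-10A cells (Homo sapiens) for cytotoxicity, read by MTT assay, with a stated time of 72 h (on this read-out lower numbers stand for stronger inhibition of growth and higher numbers for weaker inhibition of growth), compound 3 gives the lowest number of the three; compound 1 and compound 2 both sit far above it, beyond the scatter. Compound 4 `C[Se]/C(=N\C(=O)c1cc(-c2ccccc2)nc2ccccc12)NC(=O)c1cc(-c2ccccc2)nc2ccccc12` differs from compound 3 by a group of 2 heavy atoms (1 carbon, 1 selenium; no ring) in place of a group of 2 heavy atoms (1 carbon, 1 sulfur; no ring), on a carbon with a double bond to nitrogen. Going by the values given here, no measured step isolates this exchange. Among the compounds with values here, the only step touching the same carbon, a 210-fold lower number from compound 2 to compound 3 (2.33 log units; beyond the scatter), changes two things at once, the selenium for sulfur and the benzyl for methyl, so its size cannot be assigned to either part. Both selenium compounds measured, compound 1 and compound 2, give high numbers, but each differs from compound 4 elsewhere as well. For compound 4 the expected step is a 7.5-fold higher number from compound 3 to compound 4 (0.88 log units; beyond the scatter), and the size of this expected step is uncertain. The estimate for compound 4 is 300 nM, range 50 nM to 3000 nM.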

Compound 4, concentration for 50% growth inhibition: 710 nM
Compound 4: middle estimate off by 2.4-fold (0.37 log units), on the low side; measured number inside the range.
By their numbers in this assay, from the lowest: compound 3; then compound 4; then compounds 1 and 2 (each within the scatter of the next).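

In this assay, exchanging methylsulfanyl for its selenium counterpart on the carbon with a double bond to nitrogen gives an 18-fold higher number from compound 3 to compound 4 (1.25 log units; beyond the scatter), so the change of atom alone is large. With selenium kept, hydrogen in place of phenyl on the saturated chain carbon bound to selenium gives a 12-fold lower number from compound 2 to compound 4 (1.08 log units; beyond the scatter), so the earlier combined step holds two parts, each beyond the scatter. Nothing at hand accounts for either step.

Going by these compounds, it remains open whether the sulfur-to-selenium step keeps its size on the core of compound 1. Also open, on these data alone, is how an ethyl group or an amine would read at this carbon.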